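Chloro to methyl on the benzyl arm: working notes

This account rests on a few compounds, and the source may have more. Where it says the series, first, only, none or still open, it means among the compounds named here.

Measured so far:
compound 1, `Cc1cnc2sn(-c3ccc([N+](=O)[O-])cc3)c(=O)c2c1`, 15300 nM
compound 2, `O=c1c2cccnc2sn1-c1ccccc1`, 7850 nM
compound 3, `O=c1c2cccnc2sn1Cc1ccc(Cl)cc1`, 17500 nM

All three share one core and are weak in an assay for inhibition of histone acetyltransferase KAT2B (Homo sapiens), read by fluorescence; on this read-out lower numbers stand for stronger inhibition and higher numbers for weaker inhibition. Compound 3 carries the highest number of the three; its gap to compound 1 is within the scatter, so the two cannot be ordered, while its gap to compound 2 lies beyond the scatter, compound 2 having the lower number of that pair. Within the data shown here, no two measured compounds differ in only one place, so no single change has yet been calibrated in this assay.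

Compound 4, `Cc1ccc(Cn2sc3ncccc3c2=O)cc1`, is not yet measured. It is derived from compound 3 by the change (methyl in place of chloro on an aromatic carbon). Among the measured compounds shown here, nothing among the measured compounds tells how a swap of this kind behaves here, and the two groups match in count of heavy atoms, donors and acceptors. The step is therefore expected to stay within the scatter, with no direction favoured: the estimated step from compound 3 to compound 4 is a 1.0-fold lower number from compound 3 to compound 4 (0.01 log units; within the scatter).

On that basis compound 4 is estimated at 17000 nM in this assay, with a range from 8000 nM to 36000 nM.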

Compound 4, half-maximal inhibitory concentration: 27900 nM
For compound 4 the middle estimate is 1.6-fold (0.22 log units) below the measured one; the range from low to high includes it.
By their numbers in this assay, from the lowest: compounds 2, 1, 3 and 4 (each within the scatter of the next, the first and the last beyond it).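

Among these compounds, this is the first single-place comparison, and in this assay it gives a 1.6-fold higher number from compound 3 to compound 4 (0.20 log units; within the scatter), so the two compounds cannot be ordered and methyl in place of chloro on an aromatic carbon, para to a large group, has no effect that can be told from the scatter. The earlier compounds shown here could not calibrate any change, whereas this pair shows that one swap of equal heavy-atom count at this place on the benzyl arm leaves the reading unresolved, and it says so for this swap alone, without showing that the place is insensitive to other groups. No measurement at hand bears on the result beyond the values themselves.

Still open, as far as these compounds go, is whether a group of a different kind on the same aromatic carbon, such as an amine, a carboxylic acid or a methoxy group, would give a step beyond the scatter. Also open, from the compounds shown here alone, is whether methyl in place of chloro reads the same on another carbon of this ring or on a compound without the benzyl arm.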